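The source may report more compounds than this note shows. Statements on the series, on what has been measured and on what is new or still open speak of the compounds shown alone.

Two benzophenones that share one core have been tested. Compound 1 `COc1ccc(C(=O)c2cc(OC)c(OC)c(OC)c2)c(O)c1O` carries a hydroxy group at each of two neighbouring positions on its trimethoxyphenyl-free ring; in a functional assay on DU-145 cells (Homo sapiens) for cytotoxicity, read by sulforhodamine B assay, with a stated time of 48 h (on this read-out lower numbers stand for stronger inhibition of growth and higher numbers for weaker inhibition of growth), compound 1 gives 144 nM. Compound 2 `COc1ccc(C(=O)c2cc(OC)c(OC)c(OC)c2)c(OC)c1O` differs from it only by a methyl in place of hydrogen on an oxygen on an aromatic ring, and in this assay compound 2 gives 20.9 nM. For the measured compounds named here, that single methylation is the only step measured so far: a 6.9-fold lower number from compound 1 to compound 2 (0.84 log units; beyond the scatter). Compound 2 therefore stands lowest of the two numbers, with compound 1 as its nearest neighbour.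

Compound 3 `COc1ccc(C(=O)c2cc(OC)c(OC)c(OC)c2)c(OC)c1N` has not yet been measured. It differs from compound 2 as follows: amino in place of hydroxy on an aromatic carbon. Going by the values given here, no measured step touches this kind of exchange; the one known step concerns a methyl on an oxygen, not the swap of one donor-bearing heavy atom for another, so it gives no direct guide. With hydrogen-bond donor and acceptor counts unchanged, the expected step is a small one, perhaps none beyond the scatter: compound 3 is expected at 30 nM, within 8 nM to 120 nM, that is a 1.4-fold higher number from compound 2 to compound 3 (0.16 log units; within the scatter).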

Compound 3, concentration for 50% growth inhibition: 27.4 nM
Compound 3: the middle estimate sits 1.1-fold (0.04 log units) above what was measured; the range from low to high includes it.
By their numbers in this assay, from the lowest: compounds 2 and 3 (each within the scatter of the next); then compound 1.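

At the place ortho to two methoxy groups and meta to a large group, amino in place of hydroxy gives in this assay a 1.3-fold higher number from compound 2 to compound 3 (0.12 log units; within the scatter) and so stays within the scatter. For the compounds shown here, the hydroxy group at this place is therefore not the only group that keeps the number in this low range, and on this read-out compound 2 and compound 3 cannot be told apart, whereas the one earlier step, a 6.9-fold lower number from compound 1 to compound 2 (0.84 log units; beyond the scatter), concerned a methyl on another oxygen and lay beyond the scatter. No measurement to hand accounts for the close match between hydroxy and amino here.

The compounds shown leave open how far this place accepts other groups, such as a methoxy group, a methylamino group, an acetamide or a carboxylic acid, or a bare hydrogen with neither oxygen nor nitrogen on that carbon. They also leave open whether the match between hydroxy and amino holds with other groups on the shared core, or on cells other than those of this single read-out.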